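Shifting the Carboxylic Acid on a Glutamate Receptor Modulator

A few compounds are considered here, and "the series" means these few. Any claim that something is new, unique, unknown or untested is made for them only; others in the source may bear on it.

Compounds measured so far:
- compound 1, `COC(=O)c1ccc(OCCCCOc2ccc(C(=O)CC(C)C)c(O)c2C)cc1`: "not determined" (no result reported)
- compound 2, `Cc1c(OCCCCOc2ccccc2C(=O)O)ccc(C(=O)CC(C)C)c1O`: 415 nM

Two compounds share the core of compound 1, which carries an ester on its distal aryl ether and has no reported number. In an assay on HEK293 cells for positive allosteric modulation of metabotropic glutamate receptor 2 (Rattus norvegicus), read by thallium flux, with a stated time of 2.5 min (on this read-out higher numbers stand for an effect only at larger amounts of compound and lower numbers for an effect already at smaller amounts), compound 2 gives 415 nM. Among the measured compounds shown here, that is the only number, so compound 2 stands alone as the reference point, with nothing to rank it against.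

Compound 3, `Cc1c(OCCCCOc2ccc(F)c(C(=O)O)c2)ccc(C(=O)CC(C)C)c1O`, differs from compound 2 in one place: 3-carboxy-4-fluorophenyl in place of 2-carboxyphenyl on an oxygen on a saturated carbon. The carboxylic acid is kept but the ring is joined to the ether oxygen at a different position, and a fluorine is added. For the measured compounds named here, no pair of measured compounds shows what such a change does, so the direction and size of the step are open.

Going by the values given here, with no comparable step in hand, the step from compound 2 to compound 3 is expected to be a 1.6-fold higher number from compound 2 to compound 3 (0.19 log units; within the scatter), that is, a drift rather than a clear move in either direction, carried by a wide range. Compound 3 is therefore estimated at 650 nM in this assay, expected to fall between 150 nM and 2800 nM.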

Compound 3, half-maximal effective concentration: 153 nM
Estimate against measurement, compound 3: 4.2-fold (0.63 log units) above, and the stated range covers the measured number.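

In this assay, among the compounds shown here, putting 3-carboxy-4-fluorophenyl in place of 2-carboxyphenyl on an oxygen on a saturated carbon gives a 2.7-fold lower number from compound 2 to compound 3 (0.43 log units; beyond the scatter) and so supplies the first readable step. It shows that this end of the molecule is not fixed: the carboxylic acid can be placed differently on the ring, with a fluorine added, and the number still moves in the favourable direction, by a modest step that lies beyond the scatter. No measurement shown here accounts for the step, so its cause remains unknown.

The new placement of the carboxylic acid and the added fluorine arrive together in this single step, so the compounds shown do not reveal how much of the change belongs to each. They also leave open how the number would respond to a chlorine in place of the fluorine, to an amide or a tetrazole in place of the carboxylic acid, or to a shorter or longer chain between the two ether oxygens.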